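This account rests on a few compounds, and the source may have more. Where it says the series, first, only, none or still open, it means among the compounds named here.

Measured compounds in an ADME assay on HepG2 2.2.15 cells (Homo sapiens) for cytotoxicity; a higher number here means that more compound is tolerated, a lower number that less compound is tolerated:

Compound 1, `O=C(Nc1ncc(Cc2ccc(F)cc2)s1)c1ccc(Cl)cc1Cl`, gives > 50000 nM.
Compound 2, `O=C(Nc1ncc(Cc2ccc(Cl)cc2)s1)c1ccc(F)cc1F`, gives "not toxic" (no number reported).
Compound 3, `COCCCNc1ncc(C(Oc2ccc3cc(Br)ccc3c2)c2ccc(Cl)cc2)s1`, gives "not toxic" (no number reported).

The value given for compound 1 in this assay is a limit of the assay, not a number; this is the limit of > 50000 nM in this assay, at which 1 of the 3 values shown sits. For compound 2 and for compound 3 no number is reported at all in this assay, only the statement that neither was toxic. For the measured compounds named here, compound 3 therefore stands nowhere on a numerical scale: it is described in the same words as compound 2, and alongside it sits the single limit of compound 1. Going by the values given here, none of the three compounds yields a measurable half-maximal cytotoxic concentration, and no step between any two of them can be drawn.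

Compound 4, `O=S(=O)(Nc1ncc(C(Oc2ccc3cc(Br)ccc3c2)c2ccc(Cl)cc2)s1)c1cccs1`, has not been measured in this assay. It differs from compound 3 in one place, ((thiophen-2-yl)sulfonyl in place of 3-methoxypropyl on a nitrogen on an aromatic ring). Among the compounds with values here, no measured step accompanies this change, so the direction and size of any shift cannot be read from the data; with all three measured compounds tolerated to the top of the range, the expectation is for no change beyond the scatter, with the result again most likely a limit rather than a number. Compound 4 is therefore expected to give about 50000 nM, within a range from 20000 nM to 100000 nM.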

Compound 4, half-maximal cytotoxic concentration: "not toxic" (no number reported)
Nothing numeric was reported for compound 4; there is nothing to compare the estimate with.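

In this assay, compound 4 is reported only as not toxic, in the same words as compound 3, so no step can be read between compound 3 and compound 4. The compounds shown leave open at what concentration any of them becomes cytotoxic and whether (thiophen-2-yl)sulfonyl in place of 3-methoxypropyl shifts that concentration, since the only entry with a sign is compound 1's limit: the limit of > 50000 nM in this assay, at which 1 of the 4 values shown sits.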